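The source may hold more compounds than are shown below. What is called first, only, known or untested is meant among the compounds shown, and "the series" means these compounds.

Measured compounds:
Compound 1, `COc1ccc(N(C)c2nc(C)nc3ccccc23)cc1OCCN`, gives 343 nM in a functional assay on HepG2 cells (Homo sapiens) for inhibition, read by MTT assay, with a stated time of 48 h; a higher number here means a weaker inhibitor, a lower number a stronger inhibitor.
Compound 2, `Cc1nc(N(C)c2ccc([Se]C#N)c(F)c2)c2ccccc2n1`, gives 37 nM in this assay.
Compound 3, `COc1ccc(N(C)c2nc(C)nc3ccccc23)cc1OCCCCCC[Se]C#N`, gives 4890 nM in this assay.

Compound 3 stands at the highest number of the three, that is, it is the weakest inhibitor measured here. For the measured compounds named here, its nearest neighbour is compound 1, and the one step that connects them, a 14-fold higher number from compound 1 to compound 3 (1.15 log units; beyond the scatter), is the only single-place change among the measured compounds; it exchanges a small nitrogen end for the long chain ending in the selenocyanate. Going by the values given here, compound 2 is the furthest away; no single-place step joins it to compound 3, so its value shows only that a selenocyanate carried directly on the ring goes with a much lower number.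

Compound 4, `COc1ccc(N(C)c2nc(C)nc3ccccc23)cc1OCCC[Se]C#N`, differs from compound 3 as follows:
a group of 3 heavy atoms (1 carbon, 1 nitrogen, 1 selenium; no ring) in place of a group of 6 heavy atoms (4 carbon, 1 nitrogen, 1 selenium; no ring), on a saturated chain carbon, three bonds along the chain from an oxygen on an aromatic ring
The chain is shortened while the selenocyanate end stays. Among the compounds with values here, the step of a 14-fold higher number from compound 1 to compound 3 (1.15 log units; beyond the scatter) is the only measured step that bears on this, and it was large. Shortening the chain is expected to pull the number back part of the way toward compound 1, not all the way, with the outcome uncertain in size.

Compound 4 is therefore expected to give 1500 nM in this assay, with a range from 400 nM to 6000 nM.

The expected step is a 3.3-fold lower number from compound 3 to compound 4 (0.51 log units; beyond the scatter).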

Compound 4, half-maximal inhibitory concentration: 1040 nM
Estimate against measurement, compound 4: 1.4-fold (0.16 log units) above, within the range that was stated.
By their numbers in this assay, from the lowest: compound 2; then compound 1; then compound 4; then compound 3.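

Shortening the chain gives a 4.7-fold lower number from compound 3 to compound 4 (0.67 log units; beyond the scatter) in this assay while the selenocyanate end stays in place, so at this position chain length alone moves the number, something the earlier step could not show since it changed the chain and the end group together. The shorter chain does not close the whole gap, as a 3.0-fold higher number from compound 1 to compound 4 (0.48 log units; beyond the scatter) remains, which means that chain length accounts for only part of the difference between the nitrogen end and the long selenocyanate chain. No measurement given here explains either step.

For the compounds shown here, with only two selenocyanate chain lengths to compare on this oxygen, it remains open whether the number would keep falling with a still shorter chain, or whether it changes steadily or abruptly at lengths in between. On these data alone, it is also open how a thiocyanate, a nitrile or a carboxylic acid at the end of the shorter chain would compare, so the part played by the selenium atom itself cannot yet be separated from that of the chain carrying it.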